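Methyl on the Imidazole Carbon: Same Change, Second Core

This account rests on a few compounds, and the source may have more. Where it says the series, first, only, none or still open, it means among the compounds named here.

Compound 1 `O=C1NCCN1CC#CCn1ccnc1` is the reference here. In a functional assay on the whole organism for agonist activity, with Mus musculus as the target (on this read-out higher numbers stand for an effect only at larger amounts of compound and lower numbers for an effect already at smaller amounts), compound 1 gives 17.3 mg/kg. Compound 2 `Cc1cncn1CC#CCN1CCNC1=O` differs from it by methyl in place of hydrogen on an aromatic carbon. In this assay compound 2 reaches only a limit, > 100 mg/kg. Among the measured compounds shown here, compound 2 is the one value that sits at the limit of > 100 mg/kg in this assay, at which 1 of the 3 values shown sits. The change therefore cost an at least 5.7-fold higher number from compound 1 to compound 2 (0.76 log units; beyond the scatter). Compound 3 `Cn1ccn(CC#CCn2ccnc2)c1=O` carries a different core, and the difference between the two cores is not broken down here; in this assay compound 3 gives 3.7 mg/kg. Compound 4 `Cc1cncn1CC#CCn1ccn(C)c1=O` has not been measured; it differs from compound 3 by methyl in place of hydrogen on an aromatic carbon, the same change as before, at a place described in the same words. The step is expected to be a 6.8-fold higher number from compound 3 to compound 4 (0.83 log units; beyond the scatter). This rests on the measured step of an at least 5.7-fold higher number from compound 1 to compound 2 (0.76 log units; beyond the scatter). Compound 4 is accordingly estimated at 25 mg/kg, within 8 mg/kg to 100 mg/kg.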

Compound 4, dose for half-maximal effect: > 100 mg/kg
Compound 4 was reported as a limit; the forecaster's own chance of this, stated with the estimate: 25%; middle value at least 4.0-fold (0.60 log units) from the limit.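

In this assay, methyl in place of hydrogen on an aromatic carbon moved the number in the same direction on the second core as on the first, and the step here is an at least 27-fold higher number from compound 3 to compound 4 (1.43 log units; beyond the scatter). Compound 4 reaches only a limit of the assay, so the full size of this step is not known. The direction of the change thus carried over between these two cores, but whether its size did remains unsettled: the same change on two cores in this assay, an at least 5.7-fold higher number (0.76 log units; beyond the scatter) from compound 1 to compound 2 and an at least 27-fold higher number (1.43 log units; beyond the scatter) from compound 3 to compound 4; the limit leaves it open whether they differ

The compounds shown leave open whether ethyl, chlorine or a hydroxymethyl group at this place would raise the number as methyl does. They also leave open whether the same step would recur on any core beyond these two.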